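The source may hold more compounds than are shown below. What is called first, only, known or untested is meant among the compounds shown, and "the series" means these compounds.

The study sets out three measured compounds and one that awaits measurement. Compound 1 `CC(O)(CSc1ccccc1C(F)(F)F)C(=O)Nc1ccc(S(F)(F)(F)(F)F)cc1` and compound 2 `CC(O)(CSc1ccccc1OC(F)(F)F)C(=O)Nc1ccc(S(F)(F)(F)(F)F)cc1` share one core, while compound 3 `CC(O)(CSc1cccc(C(F)(F)F)c1)C(=O)Nc1cccc(S(F)(F)(F)(F)F)c1` and compound 4 `CC(O)(CSc1cccc(OC(F)(F)F)c1)C(=O)Nc1cccc(S(F)(F)(F)(F)F)c1` share another; the difference between the two cores is not broken down here. In a functional assay on DU-145 cells (Homo sapiens) for antiproliferative activity, read by propidium iodide staining, with a stated time of 96 h (on this read-out higher numbers stand for weaker inhibition and lower numbers for stronger inhibition), compound 1 gives 15800 nM, and compound 2 gives 29000 nM. The change from compound 1 to compound 2 is trifluoromethoxy in place of trifluoromethyl on an aromatic carbon and it produced a 1.8-fold higher number from compound 1 to compound 2 (0.26 log units; within the scatter). On the second core, compound 3 gives 19100 nM in this assay. Compound 4 carries the change (trifluoromethoxy in place of trifluoromethyl on an aromatic carbon). This is the same kind of change as that made on the first core, though the two places are not identical: in the first pair the group sits ortho to a large group, in the second meta to a large group. For compound 4 a step of a 1.7-fold higher number from compound 3 to compound 4 (0.24 log units; within the scatter) is expected, resting on the earlier step of a 1.8-fold higher number from compound 1 to compound 2 (0.26 log units; within the scatter), and a shift of about the same size is assumed here. On that basis compound 4 is estimated at 33000 nM in this assay, with a range from 15000 nM to 70000 nM.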

Compound 4, half-maximal inhibitory concentration: 25000 nM
Compound 4: middle estimate off by 1.3-fold (0.12 log units), on the high side; low and high end bracket the measured number.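

In this assay, putting trifluoromethoxy in place of trifluoromethyl on the second core gives a 1.3-fold higher number from compound 3 to compound 4 (0.12 log units; within the scatter), so this step, like the earlier one, stays within the scatter. Set side by side, the two steps cannot be told apart, and the change carries from one core to the other without a detectable difference: the same change on two cores in this assay, a 1.8-fold higher number (0.26 log units; within the scatter) from compound 1 to compound 2 and a 1.3-fold higher number (0.12 log units; within the scatter) from compound 3 to compound 4, 1.4-fold (0.15 log units) apart, within the scatter of two such steps. This agreement does not show that the swap has a real effect on either core, since neither step stands clear of the scatter, and two pairs that also differ in where the group sits say nothing firm about other cores in the series.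

The compounds shown leave open how the number would respond to a group of another kind at this aromatic carbon, such as an amine, a carboxylic acid or a nitrile. They also leave open whether the same small step would hold if the sulfur of the thioether were replaced by a sulfonyl group.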